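Thiazolyl ethyl ether replaces fluorophenyl oxolane at the aryl oxygen

The compounds below may be only part of what the source reports. "The series", "measured", "known", "first", "only" and "open" are said of these compounds alone.

Compound 1 `Cc1nc(C)c([C@H](OC(C)(C)C)C(=O)O)c(N2CCC(C)(C)CC2)c1-c1ccc(OCCc2ccc(F)cc2F)cc1`: in an ADME assay on microsomes from liver (Rattus norvegicus) for metabolic stability, read by LC-MS, tested at 0.5 uM (on this read-out lower numbers stand for a shorter-lived compound and higher numbers for a longer-lived compound), compound 1 reaches the assay limit, > 2 h.
Compound 2 `Cc1nc(C)c([C@H](OC(C)(C)C)C(=O)O)c(N2CCC(C)(C)CC2)c1-c1ccc(OCCc2cc(F)c(F)cc2F)cc1`: in this assay compound 2 also sits at the limit, > 2 h.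
Compound 3 `Cc1nc(C)c([C@H](OC(C)(C)C)C(=O)O)c(N2CCC(C)(C)CC2)c1-c1ccc(OC2COCC2c2ccc(F)cc2)cc1`: in this assay compound 3 likewise sits at the limit, > 2 h.

Compound 3 stands where every measured compound stands, at the limit of this assay; the three values show no separation at all (the limit of > 2 h in this assay, at which 3 of the 3 values shown sit). The steps from compound 1 to compound 2 a step that the two limits leave unreadable from compound 1 to compound 2, from compound 1 to compound 3 a step that the two limits leave unreadable from compound 1 to compound 3 and from compound 2 to compound 3 a step that the two limits leave unreadable from compound 2 to compound 3 therefore give no readable size.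

Compound 4 `Cc1nc(C)c(CCOc2ccc(-c3c(C)nc(C)c([C@H](OC(C)(C)C)C(=O)O)c3N3CCC(C)(C)CC3)cc2)s1` differs from compound 3 at the aryl oxygen: 2-(2,4-dimethyl-1,3-thiazol-5-yl)ethyl in place of 4-(4-fluorophenyl)oxolan-3-yl on an oxygen on an aromatic ring. For the measured compounds named here, no measured step bears on this change, and the two steps that touch the same oxygen are both unreadable, so no direction can be drawn from them. Compound 4 is expected to remain near the limit, with an estimated step that the limit leaves unreadable from compound 3 to compound 4. The estimate for compound 4 in this assay is 2.5 h, within 0.8 h to 6 h.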

Compound 4, half-life: > 2 h
Compound 4: a limit, no number (the forecaster's own chance of this, stated with the estimate: 60%); the middle value is on the limit's open side.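

In this assay compound 4 gives > 2 h, a limit and not a number, so its steps from compound 1, compound 2 and compound 3 cannot be read: the limit of > 2 h in this assay, at which 4 of the 4 values shown sit.

The compounds shown leave open whether the groups on the oxygen on the aromatic ring change the half-life at all, and by how much.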